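Working notes: nitro in place of methyl

The source may report more compounds than this note shows. Statements on the series, on what has been measured and on what is new or still open speak of the compounds shown alone.

The measured compounds share one core and differ at a single aromatic carbon. In a functional assay, read by Griess assay, with a stated time of 2.5 h (on this read-out lower numbers stand for stronger inhibition and higher numbers for weaker inhibition), compound 1 `COc1cc(OC)c(OC)cc1/C=C/C(=O)c1ccc(Cl)cc1` gives 2.01 ug/mL and compound 2 `COc1cc(OC)c(OC)cc1/C=C/C(=O)c1ccc(C)cc1` gives 2.18 ug/mL so compound 2 stands level with compound 1 within the scatter. The next compound is compound 3 `COc1cc(OC)c(OC)cc1/C=C/C(=O)c1ccc([N+](=O)[O-])cc1` with nitro in place of methyl on an aromatic carbon, para to a large group: nitro in place of methyl on an aromatic carbon is the counted difference. Within the data shown here, one measured step bears on this carbon, methyl in place of chloro, and it was a 1.1-fold higher number from compound 1 to compound 2 (0.04 log units; within the scatter) with nothing beyond the scatter. Among the measured compounds shown here, no measured compound carries nitro, so the range stays wide. In this assay no step beyond the scatter is expected, and the estimated step is a 1.0-fold lower number from compound 2 to compound 3 (0.02 log units; within the scatter) on this limited evidence. Compound 3 is estimated at 2.1 ug/mL with 1 ug/mL to 4.5 ug/mL as its expected range.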

Compound 3, half-maximal inhibitory concentration: 1.98 ug/mL
Compound 3: middle estimate off by 1.1-fold (0.03 log units), on the high side, within the range that was stated.
By their numbers in this assay, from the lowest: compounds 3, 1 and 2 (each within the scatter of the next).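

In this assay, nitro on this aromatic carbon, para to a large group, stays level with both earlier groups (a 1.1-fold lower number from compound 2 to compound 3 (0.04 log units; within the scatter); a 1.0-fold lower number from compound 1 to compound 3 (0.01 log units; within the scatter)). The change from methyl brings 3 heavy atoms in place of 1 and 2 hydrogen-bond acceptors in place of 0, yet methyl, chloro and nitro are not separated beyond the scatter, so these counted differences give no read on this carbon across the three compounds. No supporting measurement is at hand to explain why the three numbers sit together.

From the compounds shown here alone, whether an amine, a carboxylic acid or a longer alkyl chain on this carbon would also stay level remains open. Also open, going by these compounds, is whether the same three groups would stay level on the shared core with its methoxy groups changed.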